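Dropping the chloro from a non-toxic hydrazone

The source may hold more compounds than are shown below. What is called first, only, known or untested is meant among the compounds shown, and "the series" means these compounds.

The study measures antiproliferative activity in a functional assay on ACHN cells (Homo sapiens) for antiproliferative activity, read by sulforhodamine B assay, with a stated time of 48 h; on this read-out higher numbers stand for lower toxicity in this test and lower numbers for higher toxicity in this test. Going by the values given here, compound 1, `COc1ccc(OC)c(/C=C/c2nnc(Nc3ccc(Cl)cc3)o2)c1`, is the first entry. In this assay compound 1 returns > 100000 nM, which is a limit of the assay and not a number. Compound 2, `COc1ccc(OC)c(/C=C/C(=O)N/N=C/c2ccc(Cl)cc2)c1`, carries the same dimethoxystyryl fragment joined through an acylhydrazone to the chlorophenyl ring. In this assay compound 2 also returns > 100000 nM, again a limit and not a number. On the numbers shown, compound 2 therefore stands at the limit of > 100000 nM in this assay, at which 2 of the 2 values shown sit, so no ranking between compound 1 and compound 2 can be drawn from these readings.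

The step to compound 3, `COc1ccc(OC)c(/C=C/C(=O)N/N=C/c2ccccc2)c1`, consists of hydrogen in place of chloro on an aromatic carbon. Among the compounds with values here, no measured pair in this set isolates such a change, so no size for it is known. Given that compound 2 reads only as a limit at > 100000 nM, the step from compound 2 to compound 3 is expected to be a step that the limit leaves unreadable from compound 2 to compound 3, nothing beyond the scatter in either direction. Compound 3 is accordingly estimated at 200000 nM, with an expected range from 50000 nM to 1000000 nM, most likely reported once more as a limit.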

Compound 3, concentration lethal to 50% of the cells: > 100000 nM
Compound 3 ended at the assay's limit; the forecaster's own chance of this, stated with the estimate: 80%; the middle value is on the limit's open side.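

In this assay compound 3 reads only as a limit of the assay, as compound 2 does, so the change from 4-chlorophenyl to phenyl between them has no readable size. The compounds shown leave open how far each of them lies from that limit, and so whether the chloro matters at all for this read-out: the limit of > 100000 nM in this assay, at which 3 of the 3 values shown sit.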